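The source may report more compounds than this note shows. Statements on the series, on what has been measured and on what is new or still open speak of the compounds shown alone.

In a functional assay on BCG823 cells (Homo sapiens) for inhibition, read by MTT assay, with a stated time of 72 h (on this read-out lower numbers stand for stronger inhibition and higher numbers for weaker inhibition), compound 1 `CN(C(=O)NC(=O)c1ccc(F)c(F)c1)c1nc(C(F)(F)F)c(C(=O)N/N=C/c2ccc(C(F)(F)F)cc2)s1` gives 3.85 ug/mL. Among the measured compounds shown here, that is the higher of the two numbers measured so far, but only by a little: compound 2 `CN(C(=O)NC(=O)c1ccc(Cl)cc1Cl)c1nc(C(F)(F)F)c(C(=O)N/N=C/c2ccc(C(F)(F)F)cc2)s1` gives 3.08 ug/mL, and the step of a 1.3-fold lower number from compound 1 to compound 2 (0.10 log units; within the scatter) stays within the usual scatter of this read-out. Compound 3 `CN(C(=O)NC(=O)c1ccc(F)c(F)c1)c1nc(C(F)(F)F)c(C(=O)N/N=C/c2ccccc2C(F)(F)F)s1` has not been measured. It differs from compound 1 by 2-(trifluoromethyl)phenyl in place of 4-(trifluoromethyl)phenyl on a carbon with a double bond to nitrogen, so the change is on the other side of the shared core from where compound 1 and compound 2 differ. For the measured compounds named here, no measured step alters the aryl group on the carbon with a double bond to nitrogen, so the data give no direct guide; the one measured step, from a change on a carbonyl carbon, was small. The expectation is therefore a step of about a 1.0-fold higher number from compound 1 to compound 3 (0.01 log units; within the scatter), with no direction beyond the scatter. Compound 3 is estimated at 3.9 ug/mL, in a range from 1.5 ug/mL to 10 ug/mL.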

Compound 3, half-maximal inhibitory concentration: 3.66 ug/mL
Estimate against measurement, compound 3: 1.1-fold (0.03 log units) above; measured number inside the range.
By their numbers in this assay, from the lowest: compounds 2, 3 and 1 (each within the scatter of the next).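

Among the compounds shown here, this is the first change on the aryl group on the carbon with a double bond to nitrogen, and it shows that, in this assay, exchanging 4-(trifluoromethyl)phenyl for 2-(trifluoromethyl)phenyl gives only a small step (a 1.1-fold lower number from compound 1 to compound 3 (0.02 log units; within the scatter)). The two groups hold the same atoms, joined differently, so this rearrangement within the ring does not take the number beyond the scatter. Nothing available here explains this result.

Going by these compounds, it remains open whether this place would tolerate a more different group, such as an amine, a carboxylic acid or a plain phenyl ring without trifluoromethyl. On these data alone, the effect of combining 2-(trifluoromethyl)phenyl with the 2,4-dichlorophenyl group of compound 2 also remains open.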